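Swapping the aryl ring of compound 2: expected cell tolerance

A few compounds are considered here, and "the series" means these few. Any claim that something is new, unique, unknown or untested is made for them only; others in the source may bear on it.

Compound 1 `C=Cc1ccc(-c2cc(C)c3ncc(CSCCc4ccccc4)n3c2)cc1`: 20 ug/mL
Compound 2 `C=Cc1ccc(-c2cc(C)c3ncc(CSCc4ccccc4)n3c2)cc1`: >= 100 ug/mL
Compound 3 `Cc1cc(-c2ccc(C=O)cc2)cn2c(CSCCc3ccccc3)cnc12`: 100 ug/mL

Of the compounds shown here, three have been measured in an ADME assay on HEL cells (Homo sapiens) for cytotoxicity, with a stated time of 3 days; a higher number here means that more compound is tolerated, a lower number that less compound is tolerated. Compound 1 gives 20 ug/mL. On these data alone, for compound 2 the result is only a limit of the assay, >= 100 ug/mL, so its exact value is unknown. Compound 3 gives 100 ug/mL. Compound 2 thus sits at the top of the measured range, at the limit of >= 100 ug/mL in this assay, at which 1 of the 3 values shown sits.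

Two measured steps are known. The change phenyl in place of benzyl on a saturated chain carbon bound to a sulfur gave an at least 5.0-fold higher number from compound 1 to compound 2 (0.69 log units; beyond the scatter). The change formyl in place of vinyl on an aromatic carbon gave a 5.0-fold higher number from compound 1 to compound 3 (0.70 log units; beyond the scatter).

Compound 4 `Cc1cc(-c2ccsc2)cn2c(CSCc3ccccc3)cnc12` is not yet measured. It keeps the phenyl part of compound 2 and differs at the aryl ring: thiophen-3-yl in place of 4-vinylphenyl on an aromatic carbon. Going by the values given here, the step that touches this aryl group, a 5.0-fold higher number from compound 1 to compound 3 (0.70 log units; beyond the scatter), was modest and upward, but altered only the vinyl group; here the whole ring is exchanged, and no measured step shows such a swap. Since compound 2 already stands at the limit, little room remains for the number to rise. Compound 4 is expected to give about 100 ug/mL, within 50 ug/mL to 200 ug/mL. For compound 4 the expected step is a number no higher from compound 2 to compound 4 (the limit leaves the size open), essentially no change beyond the scatter.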

Compound 4, minimum cytotoxic concentration: 4 ug/mL
Estimate against measurement, compound 4: 25-fold (1.40 log units) above, outside the stated range (below it).
By their numbers in this assay, from the lowest: compound 4; then compound 1; then compound 3.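

Exchanging 4-vinylphenyl for thiophen-3-yl gave an at least 25-fold lower number from compound 2 to compound 4 (1.39 log units; beyond the scatter) in this assay, which shows that this aromatic carbon, para to a fused ring, is a place where a change of group can greatly lower the amount of compound the cells tolerate. Going by these compounds alone, the only earlier change at this aryl group, a 5.0-fold higher number from compound 1 to compound 3 (0.70 log units; beyond the scatter), went upward and altered just the vinyl group, so the direction of a step at this position is not fixed and depends on the change made. Compound 2 stands at a limit of the assay, so the step has a known minimum but no exact size: the limit of >= 100 ug/mL in this assay, at which 1 of the 4 values shown sits.

This single swap changes several things together: the six-membered ring of carbon only gives way to a five-membered ring with sulfur, and the double bond outside the ring is gone, so the compounds shown cannot say which of these carries the step. On these data alone, a plain phenyl or a pyridine ring at this position, or a thiophen-3-yl carrying a vinyl group, would help to separate them, and how such groups behave remains open.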